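The source may hold more compounds than are shown below. What is called first, only, known or untested is meant among the compounds shown, and "the series" means these compounds.

Values below come from a functional assay on MGC-803 cells (Homo sapiens) for antiproliferative activity, read by MTT assay, with a stated time of 48 h; on this read-out lower numbers stand for stronger inhibition and higher numbers for weaker inhibition.

compound 1 , `O=C(Nc1cccc(CNc2nccnc2Cl)c1)NC1CCCC1`, 23400 nM
compound 2 , `O=C(Nc1ccc(C(F)(F)F)cc1)Nc1cccc(CNc2nccnc2Cl)c1`, 6910 nM
compound 3 , `O=C(Nc1cccc(CNc2nccnc2Cl)c1)Nc1cccc(C(F)(F)F)c1`, 7290 nM

Compound 1 stands at the highest number of the three. Compound 3 lies lower, and compound 2 lies lower still; both of these gaps from compound 1 are beyond the scatter, so compound 1 is the weakest of the measured set in this assay. Compounds 2 and 3 sit within the scatter of each other and are not separated by these data.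

Compound 4 , `O=C(Nc1cccc(CNc2nccnc2Cl)c1)Nc1ccccc1Cl`, has not been measured. It differs from compound 1 in one place: 2-chlorophenyl in place of cyclopentyl on an amide-type nitrogen. Among the compounds with values here, no pair of measured compounds shows this particular change, so its effect is not read directly from the set. What the numbers do show is that compound 1, carrying the cyclopentyl group, gives the highest value, while compounds 2 and 3 give lower values.

Against that background compound 4 is expected to land lower than compound 1. The expected step is a 2.9-fold lower number from compound 1 to compound 4 (0.47 log units; beyond the scatter), which is expected to fall beyond the scatter. Compound 4 is not expected to land far below compounds 2 and 3. The estimate for compound 4 in this assay is 8000 nM, with a range from 3000 nM to 22000 nM.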

Compound 4, half-maximal inhibitory concentration: 7130 nM
Compound 4: middle estimate off by 1.1-fold (0.05 log units), on the high side; the range from low to high includes it.
By their numbers in this assay, from the lowest: compounds 2, 4 and 3 (each within the scatter of the next); then compound 1.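

In this assay, within the data shown here, 2-chlorophenyl in place of cyclopentyl on the amide-type nitrogen gives a 3.3-fold lower number from compound 1 to compound 4 (0.52 log units; beyond the scatter), a modest step and the first direct reading of a single change at this position. With this step, the difference between compound 1 and the aryl-bearing compounds no longer rests only on values from compounds that differ from compound 1 in more than the ring type: one change of cyclopentyl to an aromatic ring carrying chlorine is enough to cross the scatter. Compound 4 also falls within the scatter of compounds 2 and 3, so 2-chlorophenyl and the trifluoromethyl-bearing phenyl groups are not separated in this assay, and no measurement shown accounts for the step.

Going by these compounds, whether the step belongs to the aromatic ring itself or to its chlorine remains open, and plain phenyl on the same nitrogen would separate the two. On these data alone, how far this position tolerates other kinds of group, such as a benzyl group, a longer alkyl chain or a phenyl ring carrying a carboxylic acid, also remains open.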